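Ethoxy in Place of Methyl: Expected Antiproliferative Read-out

The compounds below may be only part of what the source reports. "The series", "measured", "known", "first", "only" and "open" are said of these compounds alone.

Compound 1 `Cc1ccc2nc(C(=O)Nc3c(F)cc(-c4cccc(F)c4)cc3F)c(C)c(O)c2c1` gives 37.3% in a functional assay on Hep 3B2 cells (Homo sapiens) for antiproliferative activity, read by MTT assay, with a stated time of 24 h, tested at 33.33 ug/mL; on this read-out higher numbers stand for a stronger effect at the one concentration tested and lower numbers for a weaker effect.
Compound 2 `Cc1c(C(=O)Nc2c(F)cc(-c3cccc(F)c3)cc2F)nc2ccc(C(F)(F)F)cc2c1O` gives 45.2% in this assay.
Compound 3 `Cc1ccc2nc(C(=O)Nc3c(F)cc(-c4cccc(F)c4)cc3F)c(C)c(C(=O)O)c2c1` gives 41.3% in this assay.

All three numbers sit close together. Compound 3 lies in the middle of them; its step from compound 1 is a number 4 percentage points higher from compound 1 to compound 3 (within the scatter), and compound 2 at 45.2% is likewise within the usual scatter of compound 3. Going by the values given here, no compound can be called stronger or weaker than another on these numbers.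

Compound 4 `CCOc1ccc2nc(C(=O)Nc3c(F)cc(-c4cccc(F)c4)cc3F)c(C)c(C(=O)O)c2c1` differs from compound 3 by one change: ethoxy in place of methyl on an aromatic carbon.

Among the compounds with values here, no measured step places an ethoxy anywhere on the shared core. The closest comparison is the step of a number 7.9 percentage points higher from compound 1 to compound 2 (within the scatter), which also replaces the methyl on an aromatic carbon, and the step of a number 4 percentage points higher from compound 1 to compound 3 (within the scatter) changes a different group; both are within the scatter. On this basis no shift beyond the scatter is expected in this assay, in either direction, and the expected step is a number 0.7 percentage points higher from compound 3 to compound 4 (within the scatter).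

Compound 4 is therefore estimated at 42%, with a likely range from 30% to 55%.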

Compound 4, a percentage reported as inhibition, at one concentration (the size of the read-out at that concentration, not a potency): 38.7%
For compound 4 the middle estimate is 3.3 percentage points above the measured one; measured number inside the range.
By their numbers in this assay, from the lowest: compounds 1, 4, 3 and 2 (each within the scatter of the next).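

At this position, on an aromatic carbon of a six-membered aromatic ring of carbon only, this assay gives a number 2.6 percentage points lower from compound 3 to compound 4 (within the scatter). This is the first step shown at this position that brings in oxygen: ethoxy has 3 heavy atoms and 1 hydrogen-bond acceptor, where methyl has 1 heavy atom and no acceptor, yet the step stays within the scatter. Going by these compounds alone, it is also the first step here with carboxy rather than hydroxy in the other varied place, and no measured evidence accounts for the result.

On these data alone, whether a smaller methoxy, a longer propoxy chain or an amine at this position would move the number beyond the scatter remains open. Also open, as far as these compounds go, is whether ethoxy would give a similar step with hydroxy in place of carboxy.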